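A few compounds are considered here, and "the series" means these few. Any claim that something is new, unique, unknown or untested is made for them only; others in the source may bear on it.

Compound 2 `COc1ccc(/C(=N\NC(C)=O)c2ccc3c(ccn3C)c2)c(OC)c1OC` comes from compound 1 `COc1ccc(/C(=N\N)c2ccc3c(ccn3C)c2)c(OC)c1OC` by acetyl in place of hydrogen on an amine nitrogen. Among the compounds with values here, in a functional assay on HL-60 cells (Homo sapiens) for cytotoxicity, read by XTT assay, with a stated time of 72 h (a lower number here means a stronger inhibitor, a higher number a weaker inhibitor), compound 1 gives 2000 nM, and in this assay compound 2 gives 2000 nM; the step of no change at the digits printed from compound 1 to compound 2 (within the scatter) lies within the scatter, so compound 2 stands level with compound 1, the only other compound with a value in hand.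

Compound 3 `CN/N=C(/c1ccc2c(ccn2C)c1)c1ccc(OC)c(OC)c1OC` differs from compound 2 by methyl in place of acetyl on an amine nitrogen, the acetyl leaving and a methyl entering on the amine nitrogen whose other neighbour is a double-bonded nitrogen; cut one bond further out, the change reads acetamido to methylamino. Within the data shown here, the one measured step that bears on this place, no change at the digits printed from compound 1 to compound 2 (within the scatter), shows that acetyl in place of hydrogen at the same nitrogen shifted the reading in this assay by nothing beyond the scatter. Among the measured compounds shown here, no measured step shows the methyl itself. With nothing pointing either way, the step of no change at the digits printed from compound 2 to compound 3 (within the scatter) is expected to stay within the scatter. Compound 3 is therefore estimated at 2000 nM in this assay, with a range from 1000 nM to 4000 nM.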

Compound 3, half-maximal inhibitory concentration: 1000 nM
The estimate for compound 3 lay 2.0-fold (0.30 log units) above the measured number; low and high end bracket the measured number.
By their numbers in this assay, from the lowest: compounds 3, 1 and 2 (each within the scatter of the next).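

Compound 3 carries a methyl on the amine nitrogen whose other neighbour is a double-bonded nitrogen, and in this assay methyl in place of acetyl gives a 2.0-fold lower number from compound 2 to compound 3 (0.30 log units; within the scatter), while methyl in place of hydrogen gives a 2.0-fold lower number from compound 1 to compound 3 (0.30 log units; within the scatter). This nitrogen has now carried hydrogen, acetyl and methyl, and the three readings all stay within the scatter of one another, an observation that holds for these three compounds only. Nothing at hand bears on why the readings at this nitrogen stay so close.

The compounds shown leave open whether another group on this nitrogen, such as a longer chain, a benzoyl group or a carboxylic acid, would move the reading beyond the scatter. They also leave open whether the same picture at this nitrogen would hold with other groups on the shared core, or in any read-out other than this assay.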